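Removing the Amino Group from Compound 1

The compounds below may be only part of what the source reports. "The series", "measured", "known", "first", "only" and "open" are said of these compounds alone.

Measured in a functional assay on NZB5 cells (Homo sapiens) for inhibition, read by thymidine incorporation, with a stated time of 5 days; a higher number here means a weaker inhibitor, a lower number a stronger inhibitor:
compound 1 `Cc1ccc(N)cc1S(=O)(=O)N(C)/N=C/c1cnn2ccc(C#N)cc12`: "not determined" (no result reported)
compound 2 `Cc1ccc([N+](=O)[O-])cc1CN(C)/N=C/c1cnn2ccc(C#N)cc12`: 1700 nM
compound 3 `CCc1ccc([N+](=O)[O-])cc1S(=O)(=O)N(C)/N=C/c1cnn2ccc(C#N)cc12`: 170 nM

Compound 1 cannot be placed on the scale, since in this assay compound 1 has only the entry "not determined" (no result reported). The two numbers available come from nitro-bearing relatives, and these differ from each other in more than one place. Compound 2 gives 1700 nM, while compound 3 gives 170 nM.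

The structure of interest is compound 4 `Cc1ccccc1S(=O)(=O)N(C)/N=C/c1cnn2ccc(C#N)cc12`. The change is hydrogen in place of amino on an aromatic carbon, which is hydrogen in place of amino on an aromatic carbon. With no starting number, this step cannot be checked, but it is expected to be small in this assay, with no direction favoured and nothing beyond the scatter assumed. The expectation leans on compound 3 at 170 nM, which also keeps the sulfonyl link, and the range stays wide to reflect the thin evidence. For compound 4 the expected value is 300 nM, with an estimated range of 60 nM to 1500 nM.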

Compound 4, half-maximal inhibitory concentration: > 20000 nM
Compound 4: a limit, no number; the forecaster's own chance of this, stated with the estimate: 10%; middle value at least 66-fold (1.82 log units) from the limit.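

No step can be read between compound 1 and compound 4, as neither has a number to compare. In this assay compound 4 gives > 20000 nM, which is a limit of the assay and not a number. The compounds shown leave open how far swapping amino for hydrogen shifts inhibition in this assay.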